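This account rests on a few compounds, and the source may have more. Where it says the series, first, only, none or still open, it means among the compounds named here.

Of the compounds shown here, three of this set have been tested in an ADME assay on MT4 cells (Homo sapiens) for cytotoxicity, read by MTT assay, with a stated time of 96 h (a lower number here means that less compound is tolerated, a higher number that more compound is tolerated), and all three sit at the same edge of the method. Among the measured compounds shown here, compound 1 `Nc1ncnn1/C(S)=N/C1CCCCC1` is the first of them. In this assay compound 1 gives > 100000 nM, which is a limit of the assay and not a number. Compound 3 `S=C(Nc1nc[nH]n1)Nc1ccccc1Br` is the second. In this assay compound 3 gives > 100000 nM, again a limit rather than a number. Compound 2 `S=C(Nc1ccc(Br)cc1)Nc1nc[nH]n1` is the point of departure for the step under discussion. In this assay compound 2 gives > 100000 nM, which is a limit and not a measured number. For the measured compounds named here, compound 2 therefore stands where every tested member stands, because of the limit of > 100000 nM in this assay, at which 3 of the 3 values shown sit; no compound has yet been tolerated at a concentration low enough to give a number.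

Compound 4 `Fc1ccc(NC(=S)Nc2nc[nH]n2)cc1` differs from compound 2 by fluoro in place of bromo on an aromatic carbon. Going by the values given here, no measured step between two compounds is available for this exchange, so the expectation rests only on the three limits. On that basis compound 4 is expected to remain at or beyond the limit, and the step from compound 2 to compound 4 is estimated as a step that the limit leaves unreadable from compound 2 to compound 4, that is, no change beyond the scatter. Compound 4 is accordingly expected to give about 150000 nM, within a range from 60000 nM to 400000 nM.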

Compound 4, half-maximal cytotoxic concentration: > 100000 nM
Compound 4 gave a limit, no number; the forecaster's own chance of this, stated with the estimate: 85%; the middle value is on the limit's open side.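

No step can be read from compound 2 to compound 4, because each gives only a limit and no number: the limit of > 100000 nM in this assay, at which 4 of the 4 values shown sit. The compounds shown leave open how fluoro and bromo compare here, and at what concentration any of the four compounds ceases to be tolerated.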